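A Hydroxypyridine Replaces a Sulfonamide-Bearing Phenyl Group

The source may report more compounds than this note shows. Statements on the series, on what has been measured and on what is new or still open speak of the compounds shown alone.

Compound 1, `N#Cc1cc(-c2nc(C(c3ccc(F)cc3)c3ccc(F)cc3)sc2CC(=O)O)ccc1F`: 520 nM
Compound 2, `N#Cc1ccc(-c2nc(C(c3ccc(F)cc3)c3ccc(F)cc3)sc2CC(=O)O)cc1`: 1500 nM
Compound 3, `CS(=O)(=O)Nc1cccc(-c2nc(C(c3ccc(F)cc3)c3ccc(F)cc3)sc2CC(=O)O)c1`: 370 nM

These three compounds share one core and differ only in the aromatic group attached to it; all were tested in an in vitro functional assay on HEK285-7 cells for antagonist activity at prostaglandin D2 receptor 2 (Homo sapiens), read by BRET and beta-arrestin recruitment; a higher number here means a weaker inhibitor, a lower number a stronger inhibitor. Compound 3 gives the lowest number of the three. Its step to compound 1 is within the scatter, so the two cannot be told apart, while a 4.1-fold lower number from compound 2 to compound 3 (0.61 log units; beyond the scatter) and a 2.9-fold higher number from compound 1 to compound 2 (0.46 log units; beyond the scatter) set compound 2 apart as the weakest of the set. a 1.4-fold lower number from compound 1 to compound 3 (0.15 log units; within the scatter) confirms that compound 1 and compound 3 stand close together.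

Compound 4, `O=C(O)Cc1sc(C(c2ccc(F)cc2)c2ccc(F)cc2)nc1-c1ccnc(O)c1`, has not yet been measured. It takes compound 3 and makes one change: 2-hydroxypyridin-4-yl in place of 3-(methanesulfonamido)phenyl on an aromatic carbon. Going by the values given here, no measured step involves a 2-hydroxypyridin-4-yl group, so the only guidance comes from the three steps already seen, which show that exchanging this aromatic group shifts the number by modest amounts, never by more than a 4.1-fold lower number from compound 2 to compound 3 (0.61 log units; beyond the scatter). The incoming group is the smaller of the two. A modest step in this assay is therefore expected, more likely toward a higher number than a lower one, with a 2.2-fold higher number from compound 3 to compound 4 (0.33 log units; beyond the scatter) as the estimated step. Compound 4 is expected to give about 800 nM in this assay, within a range from 250 nM to 2500 nM.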

Compound 4, half-maximal inhibitory concentration: 890 nM
For compound 4 the middle estimate is 1.1-fold (0.05 log units) below the measured one, and the stated range covers the measured number.
By their numbers in this assay, from the lowest: compounds 3, 1, 4 and 2 (each within the scatter of the next, the first and the last beyond it).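

Until now, every group at this position carried a six-membered aromatic ring of carbon only. In this assay compound 4 shows that a ring with a hetero atom can stand on this aromatic carbon and still give a number that cannot be told apart from those of the two nitrile compounds (a 1.7-fold higher number from compound 1 to compound 4 (0.23 log units; within the scatter); a 1.7-fold lower number from compound 2 to compound 4 (0.23 log units; within the scatter)). The exchange for the sulfonamide-bearing group is a modest loss (a 2.4-fold higher number from compound 3 to compound 4 (0.38 log units; beyond the scatter)), even though the leaving and entering groups have equal counts of hydrogen-bond donors and acceptors, so matching those counts did not preserve the number of compound 3. Nothing measured here explains that step.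

The compounds shown leave open how a 2-aminopyridin-4-yl or a 2-methoxypyridin-4-yl group would read at this position, which would test whether the hydroxyl itself matters to the number. They also leave open whether a methanesulfonamido group carried on a pyridine ring would match compound 3, rather than the phenyl ring it has now.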